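The source may report more compounds than this note shows. Statements on the series, on what has been measured and on what is new or still open speak of the compounds shown alone.

Measured compounds: compound 1 `Cc1nnc(SCC(=O)c2ccccc2)n1N1C(=O)c2ccccc2C1=O`, compound 2 `Cc1nnc(SCc2ccccc2Cl)n1N1C(=O)c2ccccc2C1=O`, compound 3 `CCCc1nnc(SCc2ccccc2Cl)n1N1C(=O)c2ccccc2C1=O`.

In a functional assay on MKN-45 cells (Homo sapiens) for cytotoxicity, read by MTT assay, with a stated time of 48 h (a lower number here means a stronger inhibitor, a higher number a weaker inhibitor), compound 1 gives > 200000 nM, which is a limit of the assay and not a number. Compound 2 also reaches only the limit > 200000 nM. Compound 3 likewise stops at the limit > 200000 nM. Accordingly a step that the two limits leave unreadable from compound 2 to compound 1 and a step that the two limits leave unreadable from compound 2 to compound 3; both rest on (the limit of > 200000 nM in this assay, at which 3 of the 3 values shown sit).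

Compound 4 `CCCc1nnc(SCC(=O)c2ccccc2)n1N1C(=O)c2ccccc2C1=O` has not yet been measured. It differs from compound 3 by benzoyl in place of 2-chlorophenyl on a saturated chain carbon bound to a sulfur. The same change was made from compound 2 to compound 1: benzoyl in place of 2-chlorophenyl on a saturated chain carbon bound to a sulfur. The cores of compound 2 and compound 3 differ by ethyl in place of hydrogen on a saturated chain carbon bound to an aromatic carbon. Because the limit of > 200000 nM in this assay, at which 3 of the 3 values shown sit, holds for every measured value, the step that the limit leaves unreadable from compound 3 to compound 4 is expected to stay unreadable. Compound 4 is estimated at 300000 nM in this assay, most probably again a limit.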

Compound 4, half-maximal inhibitory concentration: > 200000 nM
Compound 4: no number, only a limit; the forecaster's own chance of this, stated with the estimate: 90%; the middle value is on the limit's open side.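

No step can be read from compound 3 to compound 4 or from compound 1 to compound 4, because all four compounds stop at the same limit: the limit of > 200000 nM in this assay, at which 4 of the 4 values shown sit.

The compounds shown leave open whether either change, benzoyl in place of 2-chlorophenyl or ethyl in place of hydrogen, alters the result in this assay at all.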